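Benzyl amide variations on the benzamide-hexanamide series

The source may report more compounds than this note shows. Statements on the series, on what has been measured and on what is new or still open speak of the compounds shown alone.

Three members of the series carry the same core and differ only in the group on the amide-type nitrogen. Compound 1 `Cc1cc(C)cc(C(=O)N(CCCCCC(=O)Nc2ccccc2N)CC(=O)NC2CCCCC2)c1` gives 17500 nM in a functional assay on CAL-27 cells (Homo sapiens) for cytotoxicity, read by MTT assay, with a stated time of 72 h; a lower number here means a stronger inhibitor, a higher number a weaker inhibitor. Compound 2 `Cc1cc(C)cc(C(=O)N(CCCCCC(=O)Nc2ccccc2N)CC(=O)NCc2ccccc2)c1` gives 13700 nM in this assay, and compound 3 `Cc1ccc(CNC(=O)CN(CCCCCC(=O)Nc2ccccc2N)C(=O)c2cc(C)cc(C)c2)cc1` gives 18200 nM. Compound 3 stands at the top of the three numbers, but its steps from the others, a 1.0-fold higher number from compound 1 to compound 3 (0.02 log units; within the scatter) and a 1.3-fold higher number from compound 2 to compound 3 (0.12 log units; within the scatter), are both within the scatter, as is a 1.3-fold lower number from compound 1 to compound 2 (0.11 log units; within the scatter). Nothing in these three exchanges moves the read-out in a way that can be separated from repeat variation.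

Compound 4 `Cc1cc(C)cc(CNC(=O)CN(CCCCCC(=O)Nc2ccccc2N)C(=O)c2cc(C)cc(C)c2)c1` is compound 3 with 3,5-dimethylphenyl in place of 4-methylphenyl on a saturated chain carbon bound to an amide-type nitrogen. The step that bears on it most directly is a 1.3-fold higher number from compound 2 to compound 3 (0.12 log units; within the scatter), a methyl added on the aromatic ring, which was flat; the cyclohexyl-to-benzyl exchanges were flat as well. A second methyl on the same ring is therefore expected to give no step beyond the scatter, a 1.1-fold lower number from compound 3 to compound 4 (0.03 log units; within the scatter). Compound 4 is expected at 17000 nM, within a range of 8000 nM to 36000 nM.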

Compound 4, half-maximal inhibitory concentration: 19300 nM
Compound 4: middle estimate off by 1.1-fold (0.06 log units), on the low side; the range from low to high includes it.
By their numbers in this assay, from the lowest: compounds 2, 1, 3 and 4 (each within the scatter of the next).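

In this assay, a second methyl on the ring, 3,5-dimethylphenyl in place of 4-methylphenyl, leaves the read-out flat (a 1.1-fold higher number from compound 3 to compound 4 (0.03 log units; within the scatter)). The flatness also holds when both methyls are taken together, with 3,5-dimethylphenyl in place of phenyl giving the largest of the three new steps, which still lies within the scatter (a 1.4-fold higher number from compound 2 to compound 4 (0.15 log units; within the scatter)). Replacing cyclohexyl with 3,5-dimethylbenzyl on the amide-type nitrogen is equally flat (a 1.1-fold higher number from compound 1 to compound 4 (0.04 log units; within the scatter)), so all four carbon-only groups at this position remain within the scatter of the next in the series.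

All four compounds carry only carbon at this position and share the rest of the core. Going by these compounds, it remains open whether an amine or a carboxylic acid on the ring, or a longer chain ahead of it, would move the number beyond the scatter.

No measurement at hand bears on this flat result.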